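This account rests on a few compounds, and the source may have more. Where it says the series, first, only, none or still open, it means among the compounds named here.

Among the compounds with values here, compound 3 `CCN(Cc1ccco1)C(=O)COc1ccc(C)cc1` gives 489 nM in an assay on HEK293 cells for agonist activity at transient receptor potential cation channel subfamily M member 8 (Homo sapiens), read by fluorescence and calcium flux, with a stated time of 15 min (a higher number here means that more compound is needed for the effect, a lower number that less compound is needed), the highest of the three numbers measured so far. Compound 2 `CCN(Cc1ccoc1)C(=O)COc1ccc(C)cc1` gives 136 nM in this assay, and compound 1 `CCN(Cc1cccs1)C(=O)COc1ccc(C)cc1` gives 8 nM. Each measured step swaps one five-membered heteroaryl for another at the same place: a 61-fold higher number from compound 1 to compound 3 (1.79 log units; beyond the scatter) and a 17-fold higher number from compound 1 to compound 2 (1.23 log units; beyond the scatter) were large, while a 3.6-fold higher number from compound 2 to compound 3 (0.56 log units; beyond the scatter) was modest. Compound 4 `CCN(Cc1ccccc1)C(=O)COc1ccc(C)cc1` differs from compound 3 by phenyl in place of furan-2-yl on a saturated chain carbon bound to an amide-type nitrogen. Within the data shown here, no measured step exchanges a five-membered ring for a six-membered carbocycle, so the measured steps bear on compound 4 only by showing that this position is sensitive to the ring chosen. Because compound 1 reached 8 nM with a different aromatic ring at this place, compound 4 is expected to move toward lower numbers, with an expected step of an 8.2-fold lower number from compound 3 to compound 4 (0.91 log units; beyond the scatter) and an estimate of 60 nM between 8 nM and 500 nM.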

Compound 4, half-maximal effective concentration: 1880 nM
Compound 4: the middle estimate sits 31-fold (1.50 log units) below what was measured; the measured number lies above the stated range.
By their numbers in this assay, from the lowest: compound 1; then compound 2; then compound 3; then compound 4.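

Phenyl on a saturated chain carbon bound to an amide-type nitrogen gave a 3.8-fold higher number from compound 3 to compound 4 (0.58 log units; beyond the scatter) and a 14-fold higher number from compound 2 to compound 4 (1.14 log units; beyond the scatter) and also a 240-fold higher number from compound 1 to compound 4 (2.37 log units; beyond the scatter) in this set. A six-membered aromatic ring of carbon only therefore gave the highest number of the four, so having an aromatic ring at this place does not by itself give a low number. Nothing shown here accounts for this order of the rings. Still open, going by these compounds, is how thiophen-3-yl, pyridin-2-yl or a saturated cyclohexyl would compare at this place. Also open, on these data alone, is whether a longer chain before the thiophen-2-yl ring would keep the low number of compound 1.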